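A Smaller Ring on the Thiocarbonyl Carbon

A few compounds are considered here, and "the series" means these few. Any claim that something is new, unique, unknown or untested is made for them only; others in the source may bear on it.

Of the compounds shown here, three have so far been measured in a functional assay on HEp-2 cells (Homo sapiens) for antiproliferative activity, read by MTT assay, with a stated time of 72 h; a lower number here means a stronger inhibitor, a higher number a weaker inhibitor. Compound 1 `O=c1c(SC(=S)N2CCCC2)coc2ccc(Cl)cc12` gives 26000 nM, compound 3 `O=c1c(SC(=S)N2CCCCC2)coc2ccc(Cl)cc12` gives 12200 nM, and compound 2 `O=c1c(CSC(=S)N2CCCCC2)coc2cc(Cl)ccc12` gives 280 nM, the lowest number of the three, with both other compounds beyond the scatter. Compound 2 and compound 3 differ in more than one place; the difference between the two cores is not broken down here, and their values alone show how far compound 2 stands ahead.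

Between compound 3 and compound 1 a single change is made: pyrrolidin-1-yl in place of piperidin-1-yl on a thiocarbonyl carbon. It produced a 2.1-fold higher number from compound 3 to compound 1 (0.33 log units; beyond the scatter).

Compound 4 `O=c1c(CSC(=S)N2CCCC2)coc2cc(Cl)ccc12` has not yet been measured. It arises from compound 2 by the same change at the same place: pyrrolidin-1-yl in place of piperidin-1-yl on a thiocarbonyl carbon. A step of similar size and direction is expected here, because the earlier example of this change gave a 2.1-fold higher number from compound 3 to compound 1 (0.33 log units; beyond the scatter). For compound 4 the expected value in this assay is 600 nM, most likely lying between 250 nM and 1500 nM. That estimate means an expected step of a 2.1-fold higher number from compound 2 to compound 4 (0.33 log units; beyond the scatter).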

Compound 4, half-maximal inhibitory concentration: 2100 nM
Compound 4: middle estimate off by 3.5-fold (0.54 log units), on the low side; measured number outside the range, above it.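

In this assay, the change from piperidin-1-yl to pyrrolidin-1-yl on the thiocarbonyl carbon again weakens the compound, this time giving a 7.5-fold higher number from compound 2 to compound 4 (0.88 log units; beyond the scatter). The direction of the step therefore carries over from one core to the other, but its size does not, and the two steps are clearly different: the same change on two cores in this assay, a 2.1-fold higher number (0.33 log units; beyond the scatter) from compound 3 to compound 1 and a 7.5-fold higher number (0.88 log units; beyond the scatter) from compound 2 to compound 4, 3.5-fold (0.55 log units) apart, beyond the scatter of two such steps This shows that, for these two pairs, the earlier step was a fair guide to direction but a poor guide to size; it does not show a general rule for the series, and it does not explain why the step is larger on the core of compound 2.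

The compounds shown leave open which of the differences between the two cores goes with the larger step. They also leave open how a morpholin-4-yl ring or an open-chain diethylamino group would behave in the same place on either core.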